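Compound 3: hydrogen in place of chloro

The compounds below may be only part of what the source reports. "The series", "measured", "known", "first", "only" and "open" are said of these compounds alone.

Measured so far in a functional assay on NCI-H1650 cells (Homo sapiens) for inhibition, read by MTT assay, with a stated time of 48 h; on this read-out higher numbers stand for weaker inhibition of growth and lower numbers for stronger inhibition of growth:
compound 1 `O=S(=O)(NC1CCC2(OC1)c1ccccc1CCc1ccccc12)c1ccc(OC(F)(F)F)cc1`: 13000 nM
compound 2 `O=S(=O)(NC1CCC2(OC1)c1ccccc1CCc1ccccc12)c1ccc(Cl)cc1`: 25000 nM

Among the compounds with values here, only two numbers exist in this small series. Compound 2 at 25000 nM lies within the scatter of compound 1 at 13000 nM, so the two cannot be ranked.

The next compound to be measured is compound 3 `O=S(=O)(NC1CCC2(OC1)c1ccccc1CCc1ccccc12)c1ccccc1`. It differs from compound 2 as follows: hydrogen in place of chloro on an aromatic carbon. In words, hydrogen stands in place of chloro on an aromatic carbon, so that 4-chlorophenyl becomes phenyl.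

Within the data shown here, only one measured step bears on this exchange: a 1.9-fold higher number from compound 1 to compound 2 (0.28 log units; within the scatter), with chloro in place of trifluoromethoxy on an aromatic carbon. Among the measured compounds shown here, that step is small, but it compares two groups with each other, and no measured compound has hydrogen at this place. The evidence is therefore thin, and no shift beyond the scatter is expected in this assay, in either direction.

The expected result is no change at the digits printed from compound 2 to compound 3 (within the scatter).

Compound 3 is estimated at 25000 nM, with an expected range of 11000 nM to 55000 nM.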

Compound 3, concentration for 50% growth inhibition: 22000 nM
Estimate against measurement, compound 3: 1.1-fold (0.06 log units) above; the measured number falls inside the stated range.
By their numbers in this assay, from the lowest: compounds 1, 3 and 2 (each within the scatter of the next).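

In this assay, taking the substituent away altogether gives a 1.1-fold lower number from compound 2 to compound 3 (0.06 log units; within the scatter) and, measured against the other substituted compound, gives a 1.7-fold higher number from compound 1 to compound 3 (0.23 log units; within the scatter) as well. Within the data shown here, until now this place, on an aromatic carbon of the six-membered ring and para to a large group, had been seen only as one substituent exchanged for another, with no unsubstituted compound as a reference. With phenyl now in the series, neither chloro nor trifluoromethoxy separates from hydrogen at this place, so the three compounds cannot be ranked and neither group can be credited with any gain or loss in this assay. Nothing available bears on why the number stays within the scatter across these exchanges.

As far as these compounds go, what remains open is whether any group at this place can move the number beyond the scatter at all, for instance an amine, a carboxylic acid or a longer alkyl chain. Also open, from the compounds shown here alone, is how the number responds to changes elsewhere, since the sulfonamide link and the shared core are the same in compound 1, compound 2 and compound 3.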